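The source may hold more compounds than are shown below. What is called first, only, known or untested is meant among the compounds shown, and "the series" means these compounds.

In a functional assay on K562 cells (Homo sapiens), read by MTT assay, with a stated time of 72 h (a higher number here means a weaker inhibitor, a lower number a stronger inhibitor), compound 1 (`CNc1ncnc2c1c(-c1ccco1)cn2[C@@H]1O[C@H](CO)[C@@H](O)[C@H]1O`) gives 15100 nM as its half-maximal inhibitory concentration. Compound 2 (`Nc1nc(N)c2c(-c3ccco3)cn([C@@H]3O[C@H](CO)[C@@H](O)[C@H]3O)c2n1`) is reported only with the limit > 20000 nM and no number, so it has no exact place on the scale. Compound 3 (`Nc1nc(N)c2c(-c3ccsc3)cn([C@@H]3O[C@H](CO)[C@@H](O)[C@H]3O)c2n1`) has thiophen-3-yl in place of furan-2-yl on an aromatic carbon. For the measured compounds named here, no measured step bears on this change, and no shift beyond the usual scatter is expected in this assay in either direction. The expected step is small (an at least 1.1-fold lower number from compound 2 to compound 3 (0.04 log units; that floor lies within the scatter)). Compound 3 is estimated at 18000 nM within an expected range of 6000 nM to 40000 nM in this assay.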

Compound 3, half-maximal inhibitory concentration: > 20000 nM
Compound 3: a limit, no number (the forecaster's own chance of this, stated with the estimate: 55%); middle value at least 1.1-fold (0.04 log units) away from the limit.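

Compound 2 and compound 3 are both reported only as limits in this assay, so no step can be read between them: the limit of > 20000 nM in this assay, at which 2 of the 3 values shown sit.

Going by these compounds, whether thiophen-3-yl in place of furan-2-yl shifts the number at all stays open.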